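This account rests on a few compounds, and the source may have more. Where it says the series, first, only, none or still open, it means among the compounds named here.

Measured compounds:

Compound 1, `CC(=O)Oc1ccc(/C=C/C(=O)OCCCSc2nc(-c3ccc(S(N)(=O)=O)cc3)n(-c3ccc(F)cc3)n2)cc1OC(C)=O`: in a functional assay on A549 cells (Homo sapiens) for antiproliferative activity, read by MTT assay, with a stated time of 72 h (on this read-out higher numbers stand for weaker inhibition and lower numbers for stronger inhibition), compound 1 gives 9920 nM.
Compound 2, `CS(=O)(=O)c1ccc(-c2nc(SCCOC(=O)/C=C/c3ccc(O)c(O)c3)nn2-c2ccccc2)cc1`: in this assay compound 2 gives 13800 nM.

Only these two numbers are known, and they lie within the usual scatter of each other, so compound 2 does not stand apart from compound 1 in any direction that can be trusted. The two compounds share a related core but differ in several places at once, so nothing can be read from their pair about any single change.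

Compound 3, `NS(=O)(=O)c1ccc(-c2nc(SCCOC(=O)/C=C/c3ccc(O)c(O)c3)nn2-c2ccccc2)cc1`, is compound 2 with one small alteration: amino in place of methyl on a sulfonyl sulfur. Compound 1 already carries a sulfamoyl group on the same kind of ring, and its value sits close to that of compound 2, which gives no hint that this group by itself moves the number much. Among the measured compounds shown here, with no measured pair isolating this change, the expectation for this assay is a step from compound 2 to compound 3 of about a 1.2-fold lower number from compound 2 to compound 3 (0.06 log units; within the scatter), that is, none beyond the scatter. Compound 3 is therefore estimated at 12000 nM, with a range from 5000 nM to 30000 nM.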

Compound 3, half-maximal inhibitory concentration: 14100 nM
Beside the measured number, compound 3's estimate is 1.2-fold (0.07 log units) below it; the measured number falls inside the stated range.
By their numbers in this assay, from the lowest: compounds 1, 2 and 3 (each within the scatter of the next).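

In this assay, putting amino in place of methyl on a sulfonyl sulfur gives a 1.0-fold higher number from compound 2 to compound 3 (0.01 log units; within the scatter), so compound 2 and compound 3 cannot be told apart. Among the compounds shown here, this is the first pair here that differs in one place only, and it shows directly what the comparison with compound 1 could only hint at: with the rest of the molecule held fixed, 4-(methylsulfonyl)phenyl and 4-sulfamoylphenyl give the same result within the scatter, even though the swap adds a hydrogen-bond donor. Nothing available here accounts for this result.

The compounds shown leave open whether this sulfonyl site accepts groups of a different kind, such as a carboxylic acid or a nitrile in place of the whole methylsulfonyl group, or a larger substituted amine on the sulfur. They also leave open whether the same swap would give the same result on the background of compound 1, which differs from compound 3 in several places at once, so no single feature of it can be judged from these numbers.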